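Aryl hydrazone series: indole to phenyl

The compounds below may be only part of what the source reports. "The series", "measured", "known", "first", "only" and "open" are said of these compounds alone.

In a functional assay on MCF7 cells (Homo sapiens) for antiproliferative activity, read by MTT assay, with a stated time of 72 h (a lower number here means a stronger inhibitor, a higher number a weaker inhibitor), compound 1 `CCCSc1nc(N/N=C/c2cccs2)c2nnn(Cc3ccccc3)c2n1` reaches only the assay limit, > 64000 nM. Compound 2 `CCCSc1nc(N/N=C/c2cccnc2)c2nnn(Cc3ccccc3)c2n1` gives 58700 nM, and compound 3 `CCCSc1nc(N/N=C/c2c[nH]c3ccccc23)c2nnn(Cc3ccccc3)c2n1` gives 9010 nM, the lowest of the two numbers shown, with compound 2 the nearest. The measured steps that bring in the 1H-indol-3-yl group were an at least 7.1-fold lower number from compound 1 to compound 3 (0.85 log units; beyond the scatter) and a 6.5-fold lower number from compound 2 to compound 3 (0.81 log units; beyond the scatter). Compound 4 `CCCSc1nc(N/N=C/c2ccccc2)c2nnn(Cc3ccccc3)c2n1` differs from compound 3 by phenyl in place of 1H-indol-3-yl on a carbon with a double bond to nitrogen. Both measured steps improved on bringing in 1H-indol-3-yl, so exchanging it for phenyl should give back much of that gain: a modest step to a higher number is expected, a 4.4-fold higher number from compound 3 to compound 4 (0.65 log units; beyond the scatter). Compound 4 is expected at 40000 nM, within 12000 nM to 130000 nM, with a real chance that only a limit is returned.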

Compound 4, half-maximal inhibitory concentration: > 64000 nM
Compound 4 was reported as a limit; the forecaster's own chance of this, stated with the estimate: 35%; middle value at least 1.6-fold (0.20 log units) from the limit.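

Phenyl keeps the six-membered carbon ring of 1H-indol-3-yl without the five-membered ring and its donor, and this exchange gives an at least 7.1-fold higher number from compound 3 to compound 4 (0.85 log units; beyond the scatter) and shows that the carbon ring alone does not carry the gain. Against pyridin-3-yl, the exchange gives an at least 1.0-fold higher number from compound 2 to compound 4 (0.03 log units; that floor lies within the scatter) and so sets no order between these two compounds. The step between compound 1 and compound 4 cannot be read, as both values are limits: the limit of > 64000 nM in this assay, at which 2 of the 4 values shown sit.

Still open, from the compounds shown here alone, is whether the gain follows the donor or the larger ring system. A hydroxyl on the phenyl or a methyl on the indole nitrogen would help separate the two.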